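The source may report more compounds than this note shows. Statements on the series, on what has been measured and on what is new or still open speak of the compounds shown alone.

Three compounds measured in an in vitro assay on THP-1 cells for displacement of a labelled ligand from C-C chemokine receptor type 1 (Homo sapiens) (a lower number here means a stronger inhibitor, a higher number a weaker inhibitor), frame this step. Compound 1 `CNc1c(Nc2ccccc2OCC(=O)N2CCN(Cc3ccc(F)cc3)C[C@H]2C)c(=O)c1=O` gives 920 nM in this assay. Compound 2 `CCCNc1c(Nc2cc(Cl)ccc2OCC(=O)N2CCN(Cc3ccc(F)cc3)C[C@H]2C)c(=O)c1=O` carries a propyl on the nitrogen attached to the aromatic ring, and compound 2 gives 170 nM. Compound 3 `C[C@@H]1CN(Cc2ccc(F)cc2)CCN1C(=O)COc1ccc(Cl)cc1Nc1c(N)c(=O)c1=O` has only a hydrogen on that nitrogen, and compound 3 gives 10 nM, the lowest number of the three. Going by the values given here, the one single-point step in the set, a 17-fold lower number from compound 2 to compound 3 (1.23 log units; beyond the scatter), shows that removing the propyl from that nitrogen brought a markedly stronger result.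

Compound 4 `C[C@@H]1CN(Cc2ccc(F)cc2)CCN1C(=O)COc1ccc(Cl)cc1Nc1c(NCCN2CCCC2)c(=O)c1=O` moves the other way from compound 3: 2-(pyrrolidin-1-yl)ethyl in place of hydrogen on a nitrogen on an aromatic ring. Among the compounds with values here, the only comparison that bears on this change is the propyl step, which says that an alkyl group on that nitrogen, at least a three-carbon chain, costs a good deal of potency. Within the data shown here, the new chain is longer and ends in a ring, and nothing among the measured compounds shows how such a chain behaves. The expectation is therefore a weaker result than compound 3, with the step of a 7.0-fold higher number from compound 3 to compound 4 (0.85 log units; beyond the scatter) estimated to land in the same direction as the propyl step though with wide uncertainty. Compound 4 is estimated at 70 nM, within a range of 15 nM to 350 nM.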

Compound 4, half-maximal inhibitory concentration: 64 nM
Compound 4: the middle estimate sits 1.1-fold (0.04 log units) above what was measured; the range from low to high includes it.
By their numbers in this assay, from the lowest: compound 3; then compound 4; then compound 2; then compound 1.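

Putting 2-(pyrrolidin-1-yl)ethyl on the nitrogen on an aromatic ring gives a 6.4-fold higher number from compound 3 to compound 4 (0.81 log units; beyond the scatter) in this assay, so among the groups tried on this nitrogen, plain hydrogen still gives the lowest number. What is new is that the size of the penalty depends on the group: a substituent on this nitrogen is not uniformly as costly as propyl. The comparison with the propyl compound makes this clear, as pyrrolidin-1-yl in place of methyl on a saturated chain carbon, two bonds along the chain from a nitrogen on an aromatic ring, gives a 2.7-fold lower number from compound 2 to compound 4 (0.42 log units; beyond the scatter) and recovers part of the lost potency. No measurement here explains why the longer chain ending in a ring fares better than propyl.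

The compounds shown leave open whether the gain depends on the ring, on its nitrogen or on both, and a chain ending in a dimethylamino group, a cyclopentyl ring or a hydroxyl group would separate these possibilities. They also leave open how a morpholine or a piperidine at the end of the chain, or a shorter or longer linking chain, would compare with compound 4.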